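A few compounds are considered here, and "the series" means these few. Any claim that something is new, unique, unknown or untested is made for them only; others in the source may bear on it.

The measured compounds:

Compound 1, `O=S(=O)(Nc1ccc(-c2nc3ccccc3o2)cc1)c1cccc(O)c1`, gives in an assay on isolated protein for inhibition of malate dehydrogenase, mitochondrial (Sus scrofa), with stated times of 45 min and 30 min (on this read-out lower numbers stand for stronger inhibition and higher numbers for weaker inhibition), a value of > 63000 nM, which is a limit of the assay and not a number.

Compound 2, `CCc1ccc(S(=O)(=O)Nc2ccc(-c3nc4ccccc4o3)cc2)cc1`, gives in this assay a value of > 63000 nM, again a limit.

Compound 3, `COc1ccc(S(=O)(=O)Nc2ccc(-c3nc4ccccc4o3)cc2)cc1`, gives in this assay a value of > 63000 nM, again a limit.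

Compound 3 therefore stands exactly where the other two stand, at the limit of > 63000 nM in this assay, at which 3 of the 3 values shown sit, so no number is known for it. The steps between the measured compounds, a step that the two limits leave unreadable from compound 1 to compound 2, a step that the two limits leave unreadable from compound 1 to compound 3 and a step that the two limits leave unreadable from compound 2 to compound 3, cannot be read in size or direction because the limit of > 63000 nM in this assay, at which 3 of the 3 values shown sit, covers every value shown.

Compound 4, `O=S(=O)(Nc1ccc(-c2nc3ccccc3o2)cc1)c1ccc(Cl)cc1`, differs from compound 3 by chloro in place of methoxy on an aromatic carbon. For the measured compounds named here, no measured step offers a readable size, so the expectation rests only on where the three measured compounds sit. The expected step is a step that the limit leaves unreadable from compound 3 to compound 4, which is no change beyond the scatter. For compound 4 the estimated value in this assay is 100000 nM, with a range from 30000 nM to 400000 nM, and most likely the assay again reports only a limit.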

Compound 4, half-maximal inhibitory concentration: > 63000 nM
Compound 4: no number, only a limit (the forecaster's own chance of this, stated with the estimate: 85%); the middle value lies beyond the limit too.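

The steps from compound 1, compound 2 and compound 3 to compound 4 cannot be read in size or direction, since all four compounds sit at one limit and not at a number: the limit of > 63000 nM in this assay, at which 4 of the 4 values shown sit.

The compounds shown leave open how strongly each one inhibits the enzyme in this assay, and whether any group on the sulfonyl sulfur gives a measurable value.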